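A few compounds are considered here, and "the series" means these few. Any claim that something is new, unique, unknown or untested is made for them only; others in the source may bear on it.

Measured in a functional assay on NCI-H520 cells (Homo sapiens) for cytotoxicity; on this read-out higher numbers stand for weaker inhibition of growth and lower numbers for stronger inhibition of growth:
- compound 1 `COc1ccc(C2=C(c3ccc(SC)cc3)CC3CCCN3C2=O)cc1OC(=O)CNC(=O)OC(C)(C)C`: 7000 nM
- compound 2 `CSc1ccc(C2=C(c3ccc(F)c(F)c3)C(=O)N3CCCC3C2)cc1`: 200 nM

Compound 2 has the lower of these two numbers, 200 nM, which means stronger inhibition of growth. The gap between this number and that of compound 1, which gives 7000 nM, lies well beyond the scatter. The next molecule is compound 3 `CSc1ccc(C2=C(c3ccc(O)cc3)C(=O)N3CCCC3C2)cc1`, which has 4-hydroxyphenyl in place of 3,4-difluorophenyl on a double-bonded ring carbon.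

Going by the values given here, no measured pair here differs in one place only, so the data give no direct guide to this swap. The expectation in this assay is therefore loose: a modest move toward a higher number, close to the edge of the scatter. The estimated change is a 2.0-fold higher number from compound 2 to compound 3 (0.30 log units; within the scatter). For compound 3 the expected value is 400 nM, with an estimated range of 80 nM to 2000 nM.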

Compound 3, concentration for 50% growth inhibition: > 100000 nM
Compound 3: only a limit was reported (the forecaster's own chance of this, stated with the estimate: 5%); middle value at least 250-fold (2.39 log units) from the limit.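

Putting 4-hydroxyphenyl in place of 3,4-difluorophenyl on this double-bonded ring carbon brings, in this assay, an at least 500-fold higher number from compound 2 to compound 3 (2.69 log units; beyond the scatter), so growth inhibition here depends strongly on the group at this position. This pair isolates a single change, which compound 1 could not do, as it differs from compound 2 in more than one place. The full size of the step stays unknown, since the value of compound 3 is a limit of the assay and not a number: the limit of > 100000 nM in this assay, at which 1 of the 3 values shown sits.

The fluorine atoms leave and the hydroxyl enters in the same step, so the data do not separate the two changes. From the compounds shown here alone, how a 4-fluorophenyl or a 4-aminophenyl group would behave on this carbon remains open.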